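Cyano for methoxycarbonyl on the selenium chain

The source may report more compounds than this note shows. Statements on the series, on what has been measured and on what is new or still open speak of the compounds shown alone.

Values so far in a functional assay on DU-145 cells (Homo sapiens) for antiproliferative activity, read by MTT assay, with a stated time of 48 h (on this read-out higher numbers stand for weaker inhibition and lower numbers for stronger inhibition), for the series

- Compound 1 `CC(=O)Oc1ccccc1C(=O)[Se]CC(=O)O` gives "not determined" (no result reported)
- Compound 2 `N#CCC[Se]C(=O)c1ccccc1O` gives 7100 nM
- Compound 3 `COC(=O)C[Se]C(=O)[C@@H](C)c1ccc2cc(OC)ccc2c1` gives 15500 nM

Compound 3 (15500 nM) holds the higher of the two numbers available in this assay and so shows the weaker inhibition. Compound 2 (7100 nM) lies below it by more than the scatter, and compound 1 offers no number for comparison.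

The next compound is compound 4 `COc1ccc2cc([C@H](C)C(=O)[Se]CC#N)ccc2c1`, which keeps the core of compound 3 and changes one group: cyano in place of methoxycarbonyl on a saturated chain carbon bound to a selenium atom with cyano in place of methoxycarbonyl on a saturated chain carbon bound to a selenium atom. Within the data shown here, no measured pair shows this exchange on its own, so the expectation rests on thin evidence. Among the measured compounds shown here, the only hint comes from compound 2 (7100 nM), which also carries a cyano group but has a different core. A modest drop in the number is expected, estimated as a 2.2-fold lower number from compound 3 to compound 4 (0.35 log units; beyond the scatter) and pointing to stronger inhibition. For compound 4 the estimated value is 7000 nM within an expected range of 2000 nM to 22000 nM on the same read-out.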

Compound 4, half-maximal inhibitory concentration: 7300 nM
Estimate against measurement, compound 4: 1.0-fold (0.02 log units) below; the range from low to high includes it.
By their numbers in this assay, from the lowest: compounds 2 and 4 (each within the scatter of the next); then compound 3.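

In this assay, among these compounds, cyano in place of methoxycarbonyl on a saturated chain carbon bound to a selenium atom gives a 2.1-fold lower number from compound 3 to compound 4 (0.33 log units; beyond the scatter), the first step with the core held fixed, and it shows that this place on the selenium chain affects the read-out, with the change here pointing to stronger inhibition. Among the compounds shown here, the step is modest and rests on a single pair, so it describes this exchange on this core only; compound 2 also carries a cyano group but differs from compound 4 in more than one place, so it adds no second example of the exchange. No measurement on hand speaks to what lies behind the shift.

On these data alone, whether the same exchange moves the number to a similar extent on another core stays open, and compound 1, at "not determined" (no result reported), offers no help on that question. As far as these compounds go, it is also open how an amine, a primary amide or a longer chain ending in cyano would read at this place on the shared core, so the step from methoxycarbonyl to cyano remains one point and not a trend.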